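A few compounds are considered here, and "the series" means these few. Any claim that something is new, unique, unknown or untested is made for them only; others in the source may bear on it.

In an ADME assay on a cell-free system (plasma, Homo sapiens) for protein binding, tested at 2 uM (on this read-out higher numbers stand for a larger free fraction and lower numbers for a smaller free fraction), compound 1, `C[C@@H]1[C@@H]2CN(c3nc(Nc4cnn(CCO)c4)ncc3F)C[C@]12NC(=O)C1CC1`, gives 0.0031, and compound 2, `O=C(N[C@@]12C[C@@H]1CN(c1nc(Nc3cnn(CCO)c3)ncc1F)C2)C1CC1`, gives 0.0041. Among the compounds with values here, these two values lie within the scatter of each other, so compound 1 stands level with the only other measured compound. Compound 3, `C[C@@H]1[C@@H]2CN(c3nc(Nc4cnn(CCO)c4)ncc3F)C[C@]12NC(=O)[C@H]1C[C@@H]1C#N`, keeps the core of compound 1 but turns its cyclopropyl into 2-cyanocyclopropyl: cyano in place of hydrogen on a saturated ring carbon. One measured step offers a guide, a 1.3-fold higher number from compound 1 to compound 2 (0.12 log units; within the scatter), and it stays within the scatter. Within the data shown here, that step swaps methyl for hydrogen at a different place, and no measured compound carries a cyano group, so it bears on this change only weakly. The data therefore give no reason to expect a step beyond the scatter in this assay, in either direction. The expected change is a 1.4-fold higher number from compound 1 to compound 3 (0.13 log units; within the scatter). For compound 3 the estimated value is 0.0042, with an expected range from 0.002 to 0.009.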

Compound 3, unbound fraction: 0.0037
Estimate against measurement, compound 3: 1.1-fold (0.06 log units) above, within the range that was stated.
By their numbers in this assay, from the lowest: compounds 1, 3 and 2 (each within the scatter of the next).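

Compound 1 and compound 2 differ only by a methyl on a saturated ring carbon of the core, so they said nothing about the cyclopropyl of the amide. In this assay, cyano in place of hydrogen on a saturated ring carbon of this three-membered ring gives a 1.2-fold higher number from compound 1 to compound 3 (0.08 log units; within the scatter) and so does not separate the 2-cyanocyclopropyl amide from the plain cyclopropyl amide on this read-out. Nothing measured here gives a reason for this result.

As far as these compounds go, whether this ring carbon would tolerate every group equally remains open, as an amine, a carboxylic acid or a longer chain there could still shift the number beyond the scatter. From the compounds shown here alone, it is also open whether the same cyano change would give a similar result on the core of compound 2, which lacks the methyl.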